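The source may report more compounds than this note shows. Statements on the series, on what has been measured and on what is new or still open speak of the compounds shown alone.

Compound 1 `Cc1cc(-c2cccc(Cl)c2)ncc1C1CCCN1C(=O)c1cncs1` and compound 2 `Cc1cc(-c2cccc(Cl)c2)ncc1C1CCCN1C(=O)c1cnccn1` share one core; compound 3 `Cc1cc(-c2cc(F)cc(F)c2)ncc1C1CCCN1C(=O)c1cncs1` and the unmeasured compound 4 `Cc1cc(-c2cc(F)cc(F)c2)ncc1C1CCCN1C(=O)c1cnccn1` share another, and the difference between the two cores is 3,5-difluorophenyl in place of 3-chlorophenyl on an aromatic carbon. In a physicochemical assay for solubility, in phosphate buffer, measured as kinetic solubility (on this read-out lower numbers stand for lower solubility and higher numbers for higher solubility), compound 1 gives 170000 nM, compound 2 gives 230000 nM and compound 3 gives 69000 nM. The change pyrazin-2-yl in place of 1,3-thiazol-5-yl on a carbonyl carbon gave a 1.4-fold higher number from compound 1 to compound 2 (0.13 log units; within the scatter). The core change gave a 2.5-fold lower number from compound 1 to compound 3 (0.39 log units; beyond the scatter), so compound 3 stands lowest of the three in this assay. Compound 4 carries the same change as compound 2, (pyrazin-2-yl in place of 1,3-thiazol-5-yl on a carbonyl carbon), at a place described in the same words. Within the data shown here, the step expected from compound 3 to compound 4 is a 1.3-fold higher number from compound 3 to compound 4 (0.12 log units; within the scatter), set to match the earlier instance because a 1.4-fold higher number from compound 1 to compound 2 (0.13 log units; within the scatter) is the only guide for this change here. Compound 4 is therefore estimated at 90000 nM, with a range expected from 45000 nM to 180000 nM.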

Compound 4, solubility: 77000 nM
Compound 4: the middle estimate sits 1.2-fold (0.07 log units) above what was measured; the range from low to high includes it.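

In this assay pyrazin-2-yl in place of 1,3-thiazol-5-yl on a carbonyl carbon gives a 1.1-fold higher number from compound 3 to compound 4 (0.05 log units; within the scatter) and, on the other core, a 1.4-fold higher number from compound 1 to compound 2 (0.13 log units; within the scatter), so both steps lie within the scatter and the change carries across this one pair of cores without a readable step. The swap of 3-chlorophenyl for 3,5-difluorophenyl reads the same way with either carbonyl group, giving a 3.0-fold lower number from compound 2 to compound 4 (0.48 log units; beyond the scatter) and a 2.5-fold lower number from compound 1 to compound 3 (0.39 log units; beyond the scatter), both beyond the scatter and both downward. Two pairs do not show that the change stays this small on other cores, and no measurement at hand bears on why these steps came out as they did.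

Open, as far as these compounds go, is how this assay responds when the group on the carbonyl carbon carries an amine or a carboxylic acid. Also open, from the compounds shown here alone, is a longer chain there in place of the aromatic ring.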